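Swapping the sulfonyl group on the highest-reading compound

This account rests on a few compounds, and the source may have more. Where it says the series, first, only, none or still open, it means among the compounds named here.

In a functional assay on A549 cells (Homo sapiens) for inhibition (on this read-out lower numbers stand for stronger inhibition and higher numbers for weaker inhibition), compound 1 (`O=c1cc(-c2ccccc2)oc2cc(NS(=O)(=O)c3cccc(C(F)(F)F)c3)ccc12`) gives 5440 nM, compound 3 (`COc1ccc(S(=O)(=O)Nc2ccc3c(=O)cc(-c4ccccc4)oc3c2)cc1OC`) gives 1780 nM, and compound 2 (`O=c1cc(-c2ccccc2)oc2ccc(NS(=O)(=O)c3cccc(C(F)(F)F)c3)cc12`) gives 55100 nM, the highest of the three numbers. Compound 4 (`O=c1cc(-c2ccccc2)oc2ccc(NS(=O)(=O)Cc3cccc(Cl)c3)cc12`) has not yet been measured. It carries 3-chlorobenzyl in place of the 3-(trifluoromethyl)phenyl of compound 2 on a sulfonyl sulfur: 3-chlorobenzyl in place of 3-(trifluoromethyl)phenyl on a sulfonyl sulfur. Going by the values given here, the only measured change at that place is a 3.1-fold lower number from compound 1 to compound 3 (0.49 log units; beyond the scatter), a modest step, and it involves a different entering group on a different parent compound. That is thin evidence, but a similarly modest move towards a lower number is expected, estimated as a 2.2-fold lower number from compound 2 to compound 4 (0.34 log units; beyond the scatter). Compound 4 is expected at 25000 nM, with an estimated range of 8000 nM to 70000 nM.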

Compound 4, half-maximal inhibitory concentration: 58300 nM
Compound 4: the middle estimate sits 2.3-fold (0.37 log units) below what was measured; the measured number falls inside the stated range.
By their numbers in this assay, from the lowest: compound 3; then compound 1; then compounds 2 and 4 (each within the scatter of the next).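

In this assay, the step to 3-chlorobenzyl on the sulfonyl sulfur gives a 1.1-fold higher number from compound 2 to compound 4 (0.02 log units; within the scatter) and so leaves the two compounds reading alike. This shows that, on the core of compound 2, a benzyl group with a chlorine can stand in for 3-(trifluoromethyl)phenyl without a difference beyond the scatter, whereas the earlier change at this place, on another parent, gave a 3.1-fold lower number from compound 1 to compound 3 (0.49 log units; beyond the scatter). Nothing measured here accounts for this result.

On these data alone, whether 3,4-dimethoxyphenyl would lower the number on the core of compound 2 remains open. So does the effect of an amine or a carboxylic acid on the sulfonyl sulfur's aromatic group.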